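The source may report more compounds than this note shows. Statements on the series, on what has been measured and on what is new or still open speak of the compounds shown alone.

The shared core of the series is seen in compound 2, `Nc1cc(N)c2nc(-c3ccccc3)c(Oc3ccc(F)cc3)nc2c1`, and in a functional assay on PC-3 cells (Homo sapiens) for inhibition, read by sulforhodamine B assay, with a stated time of 48 h (on this read-out lower numbers stand for stronger inhibition of growth and higher numbers for weaker inhibition of growth), compound 2 gives 8320 nM. Compound 1, `CCOC(=O)[C@H](CCC(=O)O)NC(=O)c1ccc(Sc2nc3cc(N)cc(N)c3nc2-c2ccccc2)cc1`, carries a glutamate-bearing side chain on its aryl ring and gives 15100 nM in this assay; this lies within the scatter of the value of compound 2, so the two numbers cannot be told apart, and compound 2 simply sits at the lower end of the two numbers shown. Compound 3, `CCOC(=O)[C@H](CCC(=O)O)NC(=O)c1ccc(CNc2nc3cc(N)cc(N)c3nc2-c2ccccc2)cc1`, gives in this assay < 100000 nM, which is a limit of the assay rather than a number, as noted in the limit of < 100000 nM in this assay, at which 1 of the 3 values shown sits. Among the measured compounds shown here, no two measured compounds differ in a single place, so no measured step is available.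

Compound 4, `Nc1cc(N)c2nc(-c3ccccc3)c(NCc3ccc(F)cc3)nc2c1`, remains to be measured in this assay. It differs from compound 2 as follows: (4-fluorobenzyl)amino in place of 4-fluorophenoxy on an aromatic carbon. Compound 3 carries a related linkage and reports only a limit in this assay, which gives little to build on. The step of a 2.4-fold higher number from compound 2 to compound 4 (0.38 log units; beyond the scatter) is expected to run toward weaker inhibition of growth, modestly beyond the scatter, with considerable uncertainty. For compound 4 the estimate in this assay is 20000 nM, with a range from 5000 nM to 80000 nM.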

Compound 4, concentration for 50% growth inhibition: 3470 nM
For compound 4 the middle estimate is 5.8-fold (0.76 log units) above the measured one, outside the stated range (below it).
By their numbers in this assay, from the lowest: compound 4; then compounds 2 and 1 (each within the scatter of the next).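

In this assay, among the compounds shown here, (4-fluorobenzyl)amino in place of 4-fluorophenoxy on an aromatic carbon next to the ring nitrogen gives a 2.4-fold lower number from compound 2 to compound 4 (0.38 log units; beyond the scatter), the first step that can be read, and it runs toward stronger inhibition of growth. This position of the shared core therefore responds to the group it carries, even though the fluorine-bearing six-membered aromatic ring stays in both compounds; the entering group brings nitrogen in place of oxygen, one more heavy atom and 1 hydrogen-bond donor. Nothing measured here bears on why the number moves in this direction.

From the compounds shown here alone, whether the step follows from the nitrogen or from the added carbon stays open: a phenylamino group, with the ring directly on the nitrogen, and a benzyloxy group, with the oxygen kept and the carbon added, would separate the two. Going by these compounds, the part played by the fluorine and by the length of the link also stays open, and an unsubstituted benzylamino group and a longer 2-phenylethylamino chain would address these.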